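The compounds below may be only part of what the source reports. "The series", "measured", "known", "first", "only" and "open" are said of these compounds alone.

Two members of the series have numbers in a functional assay on thoracic aorta (Rattus norvegicus, strain Wistar), with a stated time of 15 min; a higher number here means that more compound is needed for the effect, a lower number that less compound is needed. Compound 1 `CC(C)Oc1ccc(Br)cc1C(C)NC(=O)N(C)S(=O)(=O)c1ccc(Cl)cc1` gives 43200 nM. Compound 2 `COc1ccc(Br)cc1C(C)NC(=O)N(C)S(=O)(=O)c1ccccc1` gives 16800 nM, the lower of the two, with compound 1 the nearer neighbour and the gap between them beyond the usual scatter. The next step keeps the core of compound 2 and changes a single substituent: compound 3 `COc1ccc(F)cc1C(C)NC(=O)N(C)S(=O)(=O)c1ccccc1` carries fluoro in place of bromo on an aromatic carbon. Within the data shown here, no measured pair shows this exchange, so the size of its effect in this assay is open. The expected step from compound 2 to compound 3 is a 1.9-fold higher number from compound 2 to compound 3 (0.28 log units; within the scatter), most likely a rise in the number. For compound 3 the estimate is 32000 nM, with a range of 10000 nM to 100000 nM.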

Compound 3, half-maximal effective concentration: 10000 nM
Beside the measured number, compound 3's estimate is 3.2-fold (0.51 log units) above it; measured number inside the range.
By their numbers in this assay, from the lowest: compounds 3 and 2 (each within the scatter of the next); then compound 1.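

On the aromatic carbon para to a methoxy group, fluoro in place of bromo gives a 1.7-fold lower number from compound 2 to compound 3 (0.23 log units; within the scatter) in this assay. Among these compounds, this is the first exchange that can be read at a single place, and at this position the two halogens cannot be told apart in this assay. No supporting measurement bears on the cause of this result.

As far as these compounds go, whether an amine or a nitrile on this carbon would also stay within the scatter remains open. So does whether the same exchange would read alike on the core of compound 1.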